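The compounds below may be only part of what the source reports. "The series", "measured", "known", "first", "only" and "open" are said of these compounds alone.

Measured compounds in an ADME assay (liver) for metabolic stability, with Liver microsome (Homo sapiens) as the target, read by LC-MS, using microsomes and NADPH, with a stated time of 5 min, at 37 degrees C; on this read-out lower numbers stand for slow clearance and higher numbers for fast clearance:

Compound 1 `CCn1c([C@@H](C)NS(=O)(=O)c2ccc(Cl)cc2)nc2ccccc21` gives > 100 mL.min-1.g-1, which is a limit of the assay rather than a number.
Compound 2 `CCn1c([C@@H](C)NS(=O)(=O)c2ccc(Cl)cc2)nc2ccc(C(F)(F)F)cc21` gives > 100 mL.min-1.g-1, again a limit of the assay.
Compound 3 `CCn1c([C@@H](C)NS(=O)(=O)c2ccc(NC(C)=O)c(C)c2)nc2ccc(C(F)(F)F)cc21` gives > 100 mL.min-1.g-1, also a limit of the assay.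

Compound 2 therefore stands at the ceiling of what this assay reports, and it is not alone there: the limit of > 100 mL.min-1.g-1 in this assay, at which 3 of the 3 values shown sit. Among the measured compounds shown here, no measured value separates the three compounds, and the one step between them, a step that the two limits leave unreadable from compound 1 to compound 2, cannot be read because both ends are limits; it corresponds to trifluoromethyl in place of hydrogen on an aromatic carbon.

Compound 4 `CCCn1cc(S(=O)(=O)N[C@H](C)c2nc3ccc(C(F)(F)F)cc3n2CC)c(C)n1` differs from compound 2 at the other end of the molecule: a group of 9 heavy atoms (7 carbon, 2 nitrogen; one five-membered aromatic ring with 2 hetero atoms) in place of a group of 7 heavy atoms (6 carbon, 1 chlorine; one six-membered aromatic ring of carbon only), on a sulfonyl sulfur.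

For the measured compounds named here, none of the measured steps touches the sulfonyl sulfur, so none bears directly on this change. Compound 3 carries a different group on that sulfur than compound 2, yet the two values show only that both sit at the limit. With every measured compound at the limit, the data give no reason to expect a readable step in this assay in either direction.

Compound 4 is expected to give about 120 mL.min-1.g-1, with a range from 50 mL.min-1.g-1 to 300 mL.min-1.g-1. The change this estimate implies, a step that the limit leaves unreadable from compound 2 to compound 4, is expected to lie within the scatter of the assay.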

Compound 4, intrinsic clearance in microsomes: > 100 mL.min-1.g-1
Compound 4: a limit, no number; the forecaster's own chance of this, stated with the estimate: 65%; the middle value lies beyond the limit too.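

In this assay compound 4 gives > 100 mL.min-1.g-1, which is a limit of the assay and not a number. Compound 2 also stands at a limit, so no step can be read between compound 2 and compound 4: the limit of > 100 mL.min-1.g-1 in this assay, at which 4 of the 4 values shown sit. The compounds shown leave open how far the clearance of any of them lies past that limit, and whether the change on the sulfonyl sulfur alters it.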